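A Repeated Diazepane Arm on a Choline Kinase Binder

A few compounds are considered here, and "the series" means these few. Any claim that something is new, unique, unknown or untested is made for them only; others in the source may bear on it.

Within the data shown here, compound 1 `CN1CCCN(Cc2ccc(-c3ccc(N4CCN(C)CC4)cc3)cc2)CC1` is the tighter binder of the two compounds measured so far: in an assay on isolated protein for binding affinity to choline kinase alpha (Homo sapiens), read by surface plasmon resonance (on this read-out lower numbers stand for tighter binding and higher numbers for weaker binding), compound 1 gives 769 nM, while compound 2 `CN1CCCN(Cc2ccc3ncccc3c2)CC1` gives 4000 nM, a gap beyond the usual scatter. Compound 3 `CN1CCCN(Cc2ccc(-c3ccc(CN4CCCN(C)CC4)cc3)cc2)CC1` has not yet been measured. It differs from compound 1 in one place: (4-methyl-1,4-diazepan-1-yl)methyl in place of 4-methylpiperazin-1-yl on an aromatic carbon. The core of compound 1 is kept, and the entering group repeats one already carried by that core. Among the measured compounds shown here, no measured pair shows this change, so its size is unknown. A modest gain in binding is expected, a step of a 2.2-fold lower number from compound 1 to compound 3 (0.34 log units; beyond the scatter). Compound 3 is estimated at 350 nM, within 90 nM to 1400 nM.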

Compound 3, dissociation constant: 382 nM
Beside the measured number, compound 3's estimate is 1.1-fold (0.04 log units) below it; the measured number falls inside the stated range.
By their numbers in this assay, from the lowest: compounds 3 and 1 (each within the scatter of the next); then compound 2.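

On an aromatic carbon para to a large group, the core of compound 1 accepts the (4-methyl-1,4-diazepan-1-yl)methyl arm in place of 4-methylpiperazin-1-yl with a 2.0-fold lower number from compound 1 to compound 3 (0.30 log units; within the scatter) as the step. The two compounds therefore cannot be told apart in this assay even though the entering group is larger. Nothing measured here explains this result.

From the compounds shown here alone, the ring size and the way the ring is attached change together, so their separate contributions remain open. Going by these compounds, a (4-methylpiperazin-1-yl)methyl group could separate them, while a carboxylic acid at this position remains unexplored.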